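From 2-Fluorophenyl to 3-Nitrophenyl: A Cytotoxicity Estimate

The source may hold more compounds than are shown below. What is called first, only, known or untested is meant among the compounds shown, and "the series" means these compounds.

In an ADME assay on L02 cells (Homo sapiens) for cytotoxicity, read by MTT assay, with a stated time of 24 h (a lower number here means a stronger inhibitor, a higher number a weaker inhibitor), compound 1 (`COc1cc(/C=C2\CN(S(=O)(=O)c3ccc(F)cc3)C/C(=C\c3cccc([N+](=O)[O-])c3)C2=O)cc(OC)c1OC`) gives 18800 nM and compound 2 (`COc1cc(/C=C2\CN(S(=O)(=O)c3ccc(NC(C)=O)cc3)C/C(=C\c3ccccc3F)C2=O)cc(OC)c1OC`) gives 14000 nM as its value, so the two lie within the scatter of each other. Compound 3 (`COc1cc(/C=C2\CN(S(=O)(=O)c3ccc(NC(C)=O)cc3)C/C(=C\c3cccc([N+](=O)[O-])c3)C2=O)cc(OC)c1OC`) differs from compound 2 in one place (3-nitrophenyl in place of 2-fluorophenyl on a double-bonded chain carbon bound to a double-bonded ring carbon), with 3-nitrophenyl in place of 2-fluorophenyl on a double-bonded chain carbon bound to a double-bonded ring carbon. Compound 1 also carries 3-nitrophenyl and gives 18800 nM here, so no shift beyond the scatter is expected in this assay for this change. The expected step is small (a 1.1-fold higher number from compound 2 to compound 3 (0.06 log units; within the scatter)). For compound 3 the estimated value is 16000 nM with an expected range from 8000 nM to 32000 nM in all.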

Compound 3, half-maximal inhibitory concentration: 15600 nM
The estimate for compound 3 lay 1.0-fold (0.01 log units) above the measured number; low and high end bracket the measured number.
By their numbers in this assay, from the lowest: compounds 2, 3 and 1 (each within the scatter of the next).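

In this assay, 3-nitrophenyl in place of 2-fluorophenyl on a double-bonded chain carbon bound to a double-bonded ring carbon gives a 1.1-fold higher number from compound 2 to compound 3 (0.05 log units; within the scatter) and so stays within the scatter in a direct one-place comparison. Acetamido in place of fluoro on an aromatic carbon gives a 1.2-fold lower number from compound 1 to compound 3 (0.08 log units; within the scatter) and also stays within the scatter. No measurement shown explains these small steps. From the compounds shown here alone, whether an amine or a carboxylic acid at the same chain carbon would give a step beyond the scatter remains open.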